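Swapping the Benzyl Substituent in a Sulfonamide Series

This account rests on a few compounds, and the source may have more. Where it says the series, first, only, none or still open, it means among the compounds named here.

Of the compounds shown here, three sharing one core have been measured in a functional assay on CHO cells for antagonist activity at prostaglandin E2 receptor EP1 subtype (Homo sapiens), read by FLIPR and calcium flux; on this read-out lower numbers stand for stronger inhibition and higher numbers for weaker inhibition. Compound 1 `CCc1ccccc1N(Cc1nnc(Cc2ccc(Cl)cc2)o1)S(=O)(=O)c1ccc(C)cc1` gives 316 nM in this assay. Compound 2 `COc1ccc(Cc2nnc(CN(c3cccc(Cl)c3C)S(=O)(=O)c3ccc(C)cc3)o2)cc1` gives 39.8 nM, which places it second highest of the three numbers, closest to compound 3 and furthest from compound 1. Going by the values given here, compound 3 `Cc1ccc(S(=O)(=O)N(Cc2nnc(Cc3ccc(N(C)C)cc3)o2)c2cccc(Cl)c2C)cc1` gives 20 nM; the step of a 2.0-fold lower number from compound 2 to compound 3 (0.30 log units; within the scatter) is the only one-place change measured so far. Compound 1 differs from compound 2 in more than one place, so its value can only be set beside the others, not read as a single step.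

Compound 4 `Cc1ccc(S(=O)(=O)N(Cc2nnc(Cc3cccc(Cl)c3)o2)c2cccc(Cl)c2C)cc1` has not been measured. It differs from compound 2 by 3-chlorophenyl in place of 4-methoxyphenyl on a saturated chain carbon bound to an aromatic carbon. Among the compounds with values here, no measured step follows this exact change, and the one recorded step, from compound 2 to compound 3, stayed within the scatter. The change to compound 4 is therefore expected to give a step of a 1.5-fold higher number from compound 2 to compound 4 (0.18 log units; within the scatter) in this assay, not clearly beyond the scatter. Compound 4 is estimated at 60 nM, with a range from 15 nM to 250 nM.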

Compound 4, inhibition constant: 2000 nM
Beside the measured number, compound 4's estimate is 33-fold (1.52 log units) below it; the whole stated range lies below it.
By their numbers in this assay, from the lowest: compounds 3 and 2 (each within the scatter of the next); then compound 1; then compound 4.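

At this position the earlier pair gave little warning: in this assay the swap of methoxy for dimethylamino gave a 2.0-fold lower number from compound 2 to compound 3 (0.30 log units; within the scatter) and so stayed within the scatter, whereas bringing in 3-chlorophenyl gives a 50-fold higher number from compound 2 to compound 4 (1.70 log units; beyond the scatter) and also a 100-fold higher number from compound 3 to compound 4 (2.00 log units; beyond the scatter) in this series. The group on this benzyl carbon can therefore matter greatly, although the two large steps share compound 4 and so describe a single change of outcome, in which both the substituent and its ring number differ from those of the groups it replaces. No available evidence explains this drop.

The steps cannot say whether the chlorine or its ring position carries the effect. A 3-methoxyphenyl group or a plain phenyl group at this place would help separate the two.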